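This account rests on a few compounds, and the source may have more. Where it says the series, first, only, none or still open, it means among the compounds named here.

In a functional assay on KB cells (Homo sapiens) for inhibition (on this read-out higher numbers stand for weaker inhibition and lower numbers for stronger inhibition), the three measured compounds stand as follows. Compound 1 `CC(C)c1ccc(C(c2ccccc2)c2ccc(C(C)C)cc(=O)c2O)c(O)c(=O)c1` gives 0.3 ug/mL. Compound 2 `O=C1c2ccccc2CCC1C1OCCc2ccccc21` gives 42 ug/mL. Compound 3 `COc1ccc(C(NC(C)=O)c2ccc(C(C)C)cc(=O)c2O)cc1` gives 6 ug/mL.

Compound 3 thus holds the second highest number of the three, lying nearer to compound 2 and far from compound 1, with both gaps beyond the usual scatter. Compound 4 `COc1ccc(C(c2ccc(C(C)C)cc(=O)c2O)n2c(=S)oc3ccccc32)cc1` has not yet been measured. It differs from compound 3 in one place: a group of 10 heavy atoms (7 carbon, 1 nitrogen, 1 oxygen, 1 sulfur; one five-membered aromatic ring with 2 hetero atoms, one six-membered aromatic ring of carbon only) in place of a group of 4 heavy atoms (2 carbon, 1 nitrogen, 1 oxygen; no ring), on a saturated chain carbon bound to two aromatic carbons. For the measured compounds named here, no measured pair shows what such a change does, so the expectation rests on compound 3 alone. The step of a 2.0-fold lower number from compound 3 to compound 4 (0.30 log units; within the scatter) is expected to be small, toward a somewhat lower number, and may not exceed the scatter. Compound 4 is estimated at 3 ug/mL, within the range 0.6 ug/mL to 15 ug/mL.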

Compound 4, concentration for 50% inhibition: 3.7 ug/mL
Compound 4: middle estimate off by 1.2-fold (0.09 log units), on the low side; low and high end bracket the measured number.
By their numbers in this assay, from the lowest: compound 1; then compounds 4 and 3 (each within the scatter of the next); then compound 2.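

In this assay, putting the large two-ring group in place of acetamido on this saturated chain carbon gives a 1.6-fold lower number from compound 3 to compound 4 (0.21 log units; within the scatter). This position therefore accepts a much bigger group without a change beyond the scatter, even though the hydrogen-bond donor of acetamido is gone. No measurement shown here offers an explanation for this result.

On these data alone, it remains open whether an amine or a carboxylic acid at this carbon would give a similar number. As far as these compounds go, a single phenyl ring there is equally untested by these compounds, so the size limit of this position remains unknown.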